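Piperidine to Tetrahydroisoquinoline on an Inactive Amide Pair

The source may report more compounds than this note shows. Statements on the series, on what has been measured and on what is new or still open speak of the compounds shown alone.

Compound 1 `CS(=O)(=O)c1ccc(C(=O)NCCC(=O)N2CCCCC2)cc1[N+](=O)[O-]` was examined in an assay on isolated protein for inhibition of vitamin D3 receptor (Homo sapiens), read by fluorescence polarization; a higher number here means a weaker inhibitor, a lower number a stronger inhibitor. In this assay compound 1 returns only a limit, > 60000 nM, and not a number. Compound 2 `CC1CCN(C(=O)CCCNC(=O)c2ccc(S(C)(=O)=O)c([N+](=O)[O-])c2)CC1`, a close relative, was run in the same assay. In this assay compound 2 likewise gives only a limit, > 60000 nM. Both values shown therefore sit at the limit of > 60000 nM in this assay, at which 2 of the 2 values shown sit, so compound 1 cannot be placed anywhere on a scale of numbers: it stands with compound 2 at the edge of what this assay can report.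

Compound 3 `CS(=O)(=O)c1ccc(C(=O)NCCC(=O)N2CCc3ccccc3C2)cc1[N+](=O)[O-]` differs from compound 1 by 1,2,3,4-tetrahydroisoquinolin-2-yl in place of piperidin-1-yl on a carbonyl carbon, in words 1,2,3,4-tetrahydroisoquinolin-2-yl in place of piperidin-1-yl on a carbonyl carbon. Among the compounds with values here, no step between measured compounds is available to guide this change, and the two measured values give no direction, since neither is a number. The account expects no step beyond the scatter, a number no higher from compound 1 to compound 3 (the limit leaves the size open), with a further limit the most likely outcome. Compound 3 is estimated at 60000 nM, within a range from 20000 nM to 150000 nM.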

Compound 3, half-maximal inhibitory concentration: > 60000 nM
Compound 3 gave a limit, no number; the forecaster's own chance of this, stated with the estimate: 85%; the middle value sits exactly at the limit.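

Compound 3, like compound 1, returns only a limit in this assay, so no step can be read for 1,2,3,4-tetrahydroisoquinolin-2-yl in place of piperidin-1-yl, and all the values stand at one edge of the assay: the limit of > 60000 nM in this assay, at which 3 of the 3 values shown sit. The compounds shown leave open how compound 1 and compound 3 would compare on a scale of numbers.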